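The source may hold more compounds than are shown below. What is called first, only, known or untested is meant among the compounds shown, and "the series" means these compounds.

The series shares one core, carried by compound 1 `CN(C)c1cc2[nH]c(C3CCCCC3)nc2cc1NC(=O)c1cccs1`, compound 2 `COc1ccc(C(=O)Nc2cc3nc(C4CCCCC4)[nH]c3cc2N(C)C)cc1` and compound 3 `CCCOCC(=O)Nc1cc2nc(C3CCCCC3)[nH]c2cc1N(C)C`, with only the group on the carbonyl carbon varied. In an ADME assay on Vero cells (Chlorocebus sabaeus) for cytotoxicity, read by resazurin assay, with a stated time of 3 days (on this read-out lower numbers stand for stronger inhibition and higher numbers for weaker inhibition), compound 1 stands at a limit, > 100 ug/mL. Compound 2 also stands at a limit in this assay, > 100 ug/mL. Compound 3 reaches a limit on the other side in this assay, < 50 ug/mL. The step that the two limits leave unreadable from compound 1 to compound 2 cannot be read, since both values are limits (the limit of > 100 ug/mL in this assay, at which 2 of the 3 values shown sit). The steps of an at least 2.0-fold lower number from compound 1 to compound 3 (0.30 log units; that floor lies within the scatter) and an at least 2.0-fold lower number from compound 2 to compound 3 (0.30 log units; that floor lies within the scatter) both run toward the limit at which compound 3 sits (the limit of < 50 ug/mL in this assay, at which 1 of the 3 values shown sits). Compound 4 `CN(C)c1cc2[nH]c(C3CCCCC3)nc2cc1NC(=O)c1ccc(OC(F)(F)F)cc1` differs from compound 2 by trifluoromethyl in place of methyl on an oxygen on an aromatic ring. For the measured compounds named here, no measured step touches this change; the two readable steps concern exchanging the whole group on the carbonyl carbon, and 4-methoxyphenyl is kept in compound 4. With nothing pointing toward the lower limit, compound 4 is expected to remain where compound 2 sits, at an estimated 100 ug/mL (50 ug/mL to 200 ug/mL). The implied step a number no higher from compound 2 to compound 4 (the limit leaves the size open) is expected to fall within the scatter.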

Compound 4, half-maximal inhibitory concentration: > 100 ug/mL
Compound 4 was reported as a limit; the forecaster's own chance of this, stated with the estimate: 70%; the middle value sits exactly at the limit.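

In this assay compound 4 gives > 100 ug/mL, a limit. For the compounds shown here, compound 2 gives > 100 ug/mL, also a limit, and no step from one to the other can be read. The compounds shown leave open whether methoxy to trifluoromethoxy changes the number at all.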